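Replacing the 2-isopropylphenyl group of compound 3

The source may hold more compounds than are shown below. What is called first, only, known or untested is meant among the compounds shown, and "the series" means these compounds.

In a functional assay on MCF7 cells (Homo sapiens) for inhibition, read by CCK-8 assay, with a stated time of 48 h (on this read-out lower numbers stand for stronger inhibition of growth and higher numbers for weaker inhibition of growth), compound 3 `CC(C)c1ccccc1Nc1nc(Nc2ccc(N3CCN(C)CC3)cn2)ncc1Cl` gives 4360 nM, the lowest of three numbers. Compound 1 `CN1CCN(c2ccc(Nc3ncc(Cl)c(NCc4ccc(F)cc4)n3)nc2)CC1` gives 19300 nM and compound 2 `COc1ccc(CNc2nc(Nc3ccc(N4CCN(C)CC4)cn3)ncc2Cl)cc1` gives 17300 nM, and the step of a 1.1-fold lower number from compound 1 to compound 2 (0.05 log units; within the scatter) shows no real change. Compound 4 `COc1cccc(Nc2nc(Nc3ccc(N4CCN(C)CC4)cn3)ncc2Cl)c1` carries 3-methoxyphenyl in place of 2-isopropylphenyl on a nitrogen on an aromatic ring. Among the compounds with values here, no measured step makes this exact swap. The nearest evidence is a 4.4-fold lower number from compound 1 to compound 3 (0.65 log units; beyond the scatter) and a 4.0-fold lower number from compound 2 to compound 3 (0.60 log units; beyond the scatter), both modest, and both introduce the group that compound 4 loses. Part of that gain may therefore be lost. The expected step is a 1.6-fold higher number from compound 3 to compound 4 (0.21 log units; within the scatter), small and leaning toward weaker inhibition of growth. Compound 4 is estimated at 7000 nM, with an expected range of 2800 nM to 17000 nM.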

Compound 4, concentration for 50% growth inhibition: 7540 nM
For compound 4 the middle estimate is 1.1-fold (0.03 log units) below the measured one, within the range that was stated.
By their numbers in this assay, from the lowest: compounds 3 and 4 (each within the scatter of the next); then compounds 2 and 1 (each within the scatter of the next).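

Moved from 2-isopropylphenyl to 3-methoxyphenyl on this nitrogen, the read-out holds: a 1.7-fold higher number from compound 3 to compound 4 (0.24 log units; within the scatter) stays inside the scatter, so this position tolerates more than one substituted phenyl group. Compound 4 also sits apart from both benzyl compounds, with a 2.3-fold lower number from compound 2 to compound 4 (0.36 log units; beyond the scatter) and a 2.6-fold lower number from compound 1 to compound 4 (0.41 log units; beyond the scatter), so the lower numbers are not tied to the 2-isopropylphenyl group alone. No supporting data explain these differences. The compounds shown leave open whether an amine or a carboxylic acid in place of the methoxy of compound 4 would keep this level.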